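A few compounds are considered here, and "the series" means these few. Any claim that something is new, unique, unknown or untested is made for them only; others in the source may bear on it.

Measured compounds:
Compound 1 `Cn1cncc1[C@@](N)(c1ccc(C#N)cc1)c1cc2cc(C#N)cc(-c3cccc(C#N)c3)c2o1`: 2 nM in a functional assay on QG-56 cells (Homo sapiens) for antiproliferative activity; on this read-out higher numbers stand for weaker inhibition and lower numbers for stronger inhibition
Compound 2 `Cn1cncc1[C@@](N)(c1ccc(C#N)cc1)c1cc2cc(C#N)cc(-c3cccc(F)c3)c2o1`: 2 nM in this assay
Compound 3 `Cn1cncc1C(O)(c1ccc(C#N)cc1)c1cc2cc([N+](=O)[O-])cc(-c3cccc(F)c3)c2o1`: 145 nM in this assay

Compound 1 and compound 2 share a core and differ by the change (cyano in place of fluoro on an aromatic carbon); across it no change at the digits printed from compound 2 to compound 1 (within the scatter). Compound 3 carries a different core; the difference between the two cores is not broken down here. On the numbers alone, compound 3 stands at 145 nM in this assay, far from compound 1 at 2 nM and compound 2 at 2 nM.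

Compound 4 `Cn1cncc1C(O)(c1ccc(C#N)cc1)c1cc2cc([N+](=O)[O-])cc(-c3cccc(C#N)c3)c2o1` is not yet measured. It differs from compound 3 by cyano in place of fluoro on an aromatic carbon, the same change that separates compound 2 from compound 1. Since that change gave no change at the digits printed from compound 2 to compound 1 (within the scatter), the step from compound 3 to compound 4 is expected to be about no change at the digits printed from compound 3 to compound 4 (within the scatter), on a single precedent only. Compound 4 is therefore estimated at 145 nM in this assay, between 60 nM and 350 nM.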

Compound 4, half-maximal inhibitory concentration: 22.9 nM
The estimate for compound 4 lay 6.3-fold (0.80 log units) above the measured number; measured number outside the range, below it.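

In this assay, 3-fluorophenyl to 3-cyanophenyl gives a 6.3-fold lower number from compound 3 to compound 4 (0.80 log units; beyond the scatter), so the step does not transfer at a constant size between these two cores: the same change on two cores in this assay, no change at the digits printed (within the scatter) from compound 2 to compound 1 and a 6.3-fold lower number (0.80 log units; beyond the scatter) from compound 3 to compound 4, 6.3-fold (0.80 log units) apart, beyond the scatter of two such steps. A flat result for this change on one core is therefore no safe guide to its effect on the other, and any estimate carried across these cores needs a wider margin. With a single pair on each core, this shows only that the size of the step differs between these two cores; it does not show which structural difference between them goes with the gap, nor how the change would behave on any third core.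

The compounds shown leave open whether the amine or the nitrile of the core of compound 1, as against the hydroxyl or the nitro group of the core of compound 3, goes with the difference between the steps. Also open, from the compounds shown here alone, is how a chloro or methoxy group in the same place on the aromatic ring would compare on each core.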